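The source may report more compounds than this note shows. Statements on the series, on what has been measured and on what is new or still open speak of the compounds shown alone.

The compounds examined here share a fused core carrying chloro groups and a chloromethyl-bearing benzyl arm, and they were tested in a functional assay on SK-MEL-28 cells (Homo sapiens) for cytotoxicity, read by sulforhodamine B assay, with a stated time of 48 h; a higher number here means that more compound is tolerated, a lower number that less compound is tolerated. Compound 1, with the structure `ClCc1ccc(Cn2cnc3c(Cl)ncnc32)cc1`, carries its chloromethyl group on the far side of the benzyl ring. In this assay compound 1 reached only a limit of the assay, reported as > 100000 nM. That the cells tolerated it up to this point is recorded as the limit of > 100000 nM in this assay, at which 1 of the 2 values shown sits. Compound 2, with the structure `ClCc1ccccc1Cn1cnc2c(Cl)nc(Cl)nc21`, places the chloromethyl group closer on the benzyl ring and carries two chloro groups on the core. For compound 2 the outcome in this assay is "not determined" (no result reported), so there is no number on which to place it. Going by the values given here, it therefore stands only beside the single result seen for compound 1. Compound 3, with the structure `ClCc1ccccc1Cn1cnc2c(Cl)ncnc21`, is made from compound 2 by the change (hydrogen in place of chloro on an aromatic carbon). Among the compounds with values here, no measured pair here shows what such a change does in this assay. Because compound 1 gave only > 100000 nM, compound 3 is expected to lie near the same limit, estimated at 100000 nM with a range from 30000 nM to 300000 nM.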

Compound 3, concentration lethal to 50% of the cells: 24600 nM
Estimate against measurement, compound 3: 4.1-fold (0.61 log units) above; measured number below the stated range.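

Going by these compounds alone, compound 2 has no reported result in this assay, so no step from it to compound 3 can be read. Compound 1 stands only as a limit of the assay: the limit of > 100000 nM in this assay, at which 1 of the 3 values shown sits. The compounds shown leave open what hydrogen in place of chloro does to cytotoxicity, and whether the placing of the chloromethyl group matters.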